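The source may report more compounds than this note shows. Statements on the series, on what has been measured and on what is new or still open speak of the compounds shown alone.

Compound 1 `COc1cc2c(cc1OC)C(CC(N)=O)CC2` gives 31% in a functional assay on the whole organism (strain Wistar) for inhibition, with Rattus norvegicus as the target, read by paw edema, with stated times of 60 min and 2 h, at a dose of 100 mg/kg by the oral route; a higher number here means more inhibition at the dose given (going by the name of the read-out), a lower number less inhibition. Compound 2 `CCNC(=O)CC1CCc2cc(OC)c(OC)cc21` gives 26%. Compound 3 `CCCNC(=O)CC1CCc2cc(OC)c(OC)cc21` gives 28%.

Among these three, compound 2 has the lowest number, though its steps to the other two stay within the scatter: a number 5 percentage points lower from compound 1 to compound 2 (within the scatter) and a number 2 percentage points higher from compound 2 to compound 3 (within the scatter). Nothing in these numbers sets compound 2 apart from compound 1 or compound 3 in this assay.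

Compound 4 `CCCCCCNC(=O)CC1CCc2cc(OC)c(OC)cc21` is the next compound, not yet measured. It differs from compound 2 in one place: butyl in place of hydrogen on a saturated chain carbon, two bonds along the chain from an amide-type nitrogen. Within the data shown here, the step that bears most directly on this change is the one from compound 2 to compound 3, where the same position carries a methyl instead of a hydrogen, and that step was a number 2 percentage points higher from compound 2 to compound 3 (within the scatter). The two steps from compound 1, a number 5 percentage points lower from compound 1 to compound 2 (within the scatter) and a number 3 percentage points lower from compound 1 to compound 3 (within the scatter), likewise show that lengthening the chain on the amide nitrogen has left this assay unchanged within the scatter. A longer chain is therefore expected to give no step beyond the scatter in this assay, the expected step from compound 2 to compound 4 being a number 1 percentage points higher from compound 2 to compound 4 (within the scatter). Compound 4 is accordingly estimated at 27%, with a range from 15% to 39%.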

Compound 4, a percentage reported as inhibition, in the whole organism at one dose (the size of the read-out at that dose, not a potency): 41.5%
Compound 4: middle estimate off by 14.5 percentage points, on the low side; measured number outside the range, above it.
By their numbers in this assay, from the lowest: compounds 2, 3 and 1 (each within the scatter of the next); then compound 4.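

In this assay, among these compounds, the hexyl chain on the amide-type nitrogen is the first change to move the number beyond the scatter, with a number 15.5 percentage points higher from compound 2 to compound 4 (beyond the scatter), a number 13.5 percentage points higher from compound 3 to compound 4 (beyond the scatter) and a number 10.5 percentage points higher from compound 1 to compound 4 (beyond the scatter), each step modest. Ethyl and propyl at this nitrogen had stayed within the scatter of compound 1 and of each other, so the response to chain length is not even across these compounds and shows only with hexyl. Nothing measured here gives a reason for this step.

The compounds shown leave open whether butyl or pentyl on this nitrogen would already raise the number, and whether a longer chain than hexyl would raise it further. They also leave open how a chain ending in an amine or a carboxylic acid would compare with hexyl at this place.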